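A few compounds are considered here, and "the series" means these few. Any claim that something is new, unique, unknown or untested is made for them only; others in the source may bear on it.

Measured in an ADME assay on microsomes from liver (Homo sapiens) for metabolic stability, with a stated time of 60 min, tested at 1 uM; on this read-out higher numbers stand for a more stable compound and lower numbers for a less stable compound:
- compound 1 `COc1cc(-c2cnn3cc(OC)c(-c4cnn(C)c4)nc23)ccn1`: 43%
- compound 2 `CNc1nc2c(-c3ccnc(OC)c3)cnn2cc1OC`: 63%

Compound 2, at 63%, holds the higher of the two numbers in this assay, and the gap to compound 1 lies beyond the usual scatter. The next compound to read is compound 3 `COc1cnc2c(-c3ccnc(OC)c3)cnn2c1`, not yet measured. It has hydrogen in place of methylamino on an aromatic carbon.

Going by the values given here, only one measured step bears on this change. It concerns the same aromatic carbon, with methylamino in place of 1-methyl-1H-pyrazol-4-yl: a number 20 percentage points higher from compound 1 to compound 2 (beyond the scatter), a modest step. It shows that the group on this carbon can shift the read-out. Among the compounds with values here, no measured compound carries hydrogen there, however, so the direction of the next step is poorly fixed. The expected step is small, estimated as a number 4 percentage points higher from compound 2 to compound 3 (within the scatter), and it may well not clear the scatter. For compound 3 the estimated value in this assay is 67%, with an expected range from 45% to 87%.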

Compound 3, percent of the compound remaining: 2%
For compound 3 the middle estimate is 65 percentage points above the measured one, outside the stated range (below it).
By their numbers in this assay, from the lowest: compound 3; then compound 1; then compound 2.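

In this assay, the bare aromatic carbon marks the low end of this short series: hydrogen in place of methylamino gives a number 61 percentage points lower from compound 2 to compound 3 (beyond the scatter), and hydrogen in place of 1-methyl-1H-pyrazol-4-yl gives a number 41 percentage points lower from compound 1 to compound 3 (beyond the scatter). The earlier comparison set one substituent against another, with a number 20 percentage points higher from compound 1 to compound 2 (beyond the scatter), and gave no reference point for the unsubstituted carbon. With that reference now in place, both substituents stand well above hydrogen, and compound 3 is the least stable of the three, so the read-out at this position depends far more on having either of these groups than on the choice between them.

Going by these compounds, whether a simple amine, a methyl group or a chlorine atom on this carbon would keep the number near that of compound 2 remains open, and so does which feature shared by methylamino and 1-methyl-1H-pyrazol-4-yl matters, if any single one does. The data at hand offer no explanation for the sharp loss on removing either group.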